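Thiophen-2-yl Replaces 2-Fluorophenyl on a Shared Core

The compounds below may be only part of what the source reports. "The series", "measured", "known", "first", "only" and "open" are said of these compounds alone.

Compound 3 `Fc1ccccc1-c1cn2ccnc2c(-c2ccc3ncn(C4CCCCC4)c3c2)n1` carries the lowest number of the three compounds measured in a functional assay on RPMI-8226 cells (Homo sapiens) for inhibition, read by sulforhodamine B assay, with a stated time of 48 h, tested at 10 uM; on this read-out higher numbers stand for more inhibition at the one concentration tested (going by the name of the read-out) and lower numbers for less inhibition; in this assay compound 3 gives 42.4%. Its nearest neighbour is compound 2 `Fc1ccc(-c2cn3ccnc3c(-c3ccc4ncn(C5CCCCC5)c4c3)n2)cc1`, which gives 50.1%, and the gap a number 7.7 percentage points lower from compound 2 to compound 3 (within the scatter) is within the scatter. The furthest is compound 1 `O=Cc1ccc(-c2cn3ccnc3c(-c3ccc4ncn(C5CCCCC5)c4c3)n2)cc1`, which gives 82.5%, and the drop a number 40.1 percentage points lower from compound 1 to compound 3 (beyond the scatter) is large, as is a number 32.4 percentage points lower from compound 1 to compound 2 (beyond the scatter).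

Compound 4 `c1csc(-c2cn3ccnc3c(-c3ccc4ncn(C5CCCCC5)c4c3)n2)c1` has not yet been measured. It differs from compound 3 in one place: thiophen-2-yl in place of 2-fluorophenyl on an aromatic carbon. For the measured compounds named here, no measured step exchanges the six-membered ring for a five-membered ring. Going by the values given here, the nearest precedent, the move between 4-fluorophenyl and 2-fluorophenyl, a number 7.7 percentage points lower from compound 2 to compound 3 (within the scatter), stayed within the scatter, while the formyl-to-fluoro exchange, a number 32.4 percentage points lower from compound 1 to compound 2 (beyond the scatter), was large. The step of a number 2.6 percentage points higher from compound 3 to compound 4 (within the scatter) is therefore expected to be modest and of uncertain direction. Compound 4 is estimated at 45%, within a range from 25% to 65%.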

Compound 4, a percentage reported as inhibition, at one concentration (the size of the read-out at that concentration, not a potency): 52.3%
Beside the measured number, compound 4's estimate is 7.3 percentage points below it, within the range that was stated.
By their numbers in this assay, from the lowest: compounds 3, 2 and 4 (each within the scatter of the next); then compound 1.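

In this assay, replacing the six-membered carbon ring with the smaller thiophen-2-yl ring on this aromatic carbon, next to the ring nitrogen, gave a number 9.9 percentage points higher from compound 3 to compound 4 (within the scatter) and, against the 4-fluorophenyl group, a number 2.2 percentage points higher from compound 2 to compound 4 (within the scatter). This position therefore accepts a five-membered aromatic ring with a sulfur atom without a change beyond the scatter, so neither ring size nor the fluorine separates these three compounds. The 4-formylphenyl group still stands apart, with a number 30.2 percentage points lower from compound 1 to compound 4 (beyond the scatter), and nothing available explains this difference or the lack of one among the other three.

From the compounds shown here alone, it remains open whether the high reading of compound 1 depends on the formyl group itself or would also be seen with a carboxylic acid or an amine on the phenyl ring. Going by these compounds, it is equally open whether a formyl group on the thiophen-2-yl ring would give a similar reading.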